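From 2-methylphenyl to 3-methoxyphenyl: compound 3 to compound 4

The source may hold more compounds than are shown below. What is called first, only, known or untested is meant among the compounds shown, and "the series" means these compounds.

In a functional assay on LoVo cells (Homo sapiens) for inhibition, read by MTT assay, with a stated time of 24 h (on this read-out higher numbers stand for weaker inhibition and lower numbers for stronger inhibition), compound 1 `CC1(C)[C@H]2CC[C@]1(C)N(Cc1cn(-c3cccc(C#N)c3)nn1)C(=O)C2` gives 320 nM, compound 2 `COc1ccccc1-n1cc(CN2C(=O)C[C@@H]3CC[C@@]2(C)C3(C)C)nn1` gives 70 nM and compound 3 `Cc1ccccc1-n1cc(CN2C(=O)C[C@@H]3CC[C@@]2(C)C3(C)C)nn1` gives 80 nM. Compound 3 therefore stands level with compound 2, with a 1.1-fold higher number from compound 2 to compound 3 (0.06 log units; within the scatter), and both stand clearly under compound 1.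

The next change leads to compound 4 `COc1cccc(-n2cc(CN3C(=O)C[C@@H]4CC[C@@]3(C)C4(C)C)nn2)c1`: 3-methoxyphenyl in place of 2-methylphenyl on an aromatic nitrogen, (3-methoxyphenyl in place of 2-methylphenyl on an aromatic nitrogen). Within the data shown here, no measured step makes this exact change. The nearest evidence comes from the two steps that replace 3-cyanophenyl, a 4.6-fold lower number from compound 1 to compound 2 (0.66 log units; beyond the scatter) and a 4.0-fold lower number from compound 1 to compound 3 (0.60 log units; beyond the scatter), both modest. These steps change the group and its ring numbering together, so the data cannot separate the two. Compound 4 carries the methoxy group of compound 2 but has the ring numbering of the 3-cyanophenyl in compound 1. The expectation therefore places compound 4 between the two measured levels, leaning towards neither, on the evidence of a 4.6-fold lower number from compound 1 to compound 2 (0.66 log units; beyond the scatter) and a 4.0-fold lower number from compound 1 to compound 3 (0.60 log units; beyond the scatter). The estimated step is a 2.1-fold higher number from compound 3 to compound 4 (0.33 log units; beyond the scatter), towards a higher number and so weaker inhibition. For compound 4 the estimated value is 170 nM, with an expected range of 70 nM to 400 nM.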

Compound 4, half-maximal inhibitory concentration: 80 nM
The estimate for compound 4 lay 2.1-fold (0.33 log units) above the measured number; the range from low to high includes it.
By their numbers in this assay, from the lowest: compounds 2, 3 and 4 (each within the scatter of the next); then compound 1.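

In this assay, the step of no change at the digits printed from compound 3 to compound 4 (within the scatter) swaps 2-methylphenyl for 3-methoxyphenyl, and the step of a 1.1-fold higher number from compound 2 to compound 4 (0.06 log units; within the scatter) swaps 2-methoxyphenyl for 3-methoxyphenyl, so at this place on the aromatic nitrogen the change of ring numbering on the methoxyphenyl group leaves the number unmoved. Among these compounds, the step of a 4.0-fold lower number from compound 1 to compound 4 (0.60 log units; beyond the scatter) is the first here in which methoxy replaces cyano with the ring numbering held, which ties the gap between compound 1 and the other three compounds to the nitrile rather than to the ring numbering, at least within these four compounds. No measurement of any property of these groups is available to account for the result.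

The compounds shown leave open whether the higher number of compound 1 is particular to the nitrile or also appears with a carboxylic acid or an amine in its place on the phenyl ring. They also leave open whether the level shared by compound 2, compound 3 and compound 4 would hold with a longer alkoxy chain in place of methoxy.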